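The source may hold more compounds than are shown below. What is called first, only, known or untested is meant among the compounds shown, and "the series" means these compounds.

Working notes on the series. Compound 1 `Fc1ccc(-c2cn3ccnc3c(-c3ccc4ncn(C5CCCCC5)c4c3)n2)cc1` gives 2.01 in a physicochemical assay for lipophilicity, using the shake flask method, in phosphate buffer, measured as octanol-water partition, with a stated time of 85 min, at pH 7.4; on this read-out lower numbers stand for lower lipophilicity and higher numbers for higher lipophilicity; among the three numbers shown it stands second highest, with compound 2 nearest and compound 3 furthest. Compound 2 `CC(=O)c1ccc(-c2cn3ccnc3c(-c3ccc4ncn(C5CCCCC5)c4c3)n2)cc1` gives 2.06 and compound 3 `Brc1ccc(-c2cn3ccnc3c(-c3ccc4ncn(C5CCCCC5)c4c3)n2)cc1` gives 1.73. The steps at the aromatic carbon run a number 0.05 log units higher from compound 1 to compound 2 (within the scatter), a number 0.28 log units lower from compound 1 to compound 3 (within the scatter) and a number 0.33 log units lower from compound 2 to compound 3 (beyond the scatter). Compound 4 `FC(F)(F)c1cccc(-c2cn3ccnc3c(-c3ccc4ncn(C5CCCCC5)c4c3)n2)c1` differs from compound 1 by 3-(trifluoromethyl)phenyl in place of 4-fluorophenyl on an aromatic carbon. Among the compounds with values here, no measured step brings in a trifluoromethyl group, and none alters where the substituent sits on the phenyl ring; the closest evidence is the pair of exchanges from compound 1, both within the scatter. A step of a number 0.19 log units higher from compound 1 to compound 4 (within the scatter) is therefore expected, at most a small rise. The estimate for compound 4 in this assay is 2.2, ranging from 1.8 to 2.6.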

Compound 4, partition coefficient: 1.72
For compound 4 the middle estimate is 0.48 log units above the measured one; measured number below the stated range.
By their numbers in this assay, from the lowest: compounds 4, 3, 1 and 2 (each within the scatter of the next, the first and the last beyond it).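

In this assay the exchange to 3-(trifluoromethyl)phenyl on this aromatic carbon gives a number 0.29 log units lower from compound 1 to compound 4 (within the scatter) and a number 0.01 log units lower from compound 3 to compound 4 (within the scatter) so it reads level with both 4-fluorophenyl and 4-bromophenyl. Against 4-acetylphenyl it gives a number 0.34 log units lower from compound 2 to compound 4 (beyond the scatter) as a second step beyond the scatter at this position, both such steps starting from compound 2. Nothing shown accounts for these steps. The compounds shown do not separate the trifluoromethyl group from its place on the phenyl ring, and how an amine or a carboxylic acid on that ring would read stays open.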